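From Chloro to Methoxy on an Aromatic Ring

The compounds below may be only part of what the source reports. "The series", "measured", "known", "first", "only" and "open" are said of these compounds alone.

Measured compounds:
compound 1 `COC(=O)CN(C)c1nc(Nc2ccc(Cl)cc2)ncc1[N+](=O)[O-]` — 23500 nM
compound 2 `CCOC(=O)CNc1nc(Nc2ccc(Cl)cc2)ncc1[N+](=O)[O-]` — > 100000 nM
compound 3 `CCOC(=O)CN(Cc1ccccc1)c1nc(Nc2ccc(Cl)cc2)ncc1[N+](=O)[O-]` — > 100000 nM

Three compounds with a shared core were tested in a functional assay on A549 cells (Homo sapiens) for antiproliferative activity, read by MTT assay, with a stated time of 48 h; on this read-out lower numbers stand for stronger inhibition and higher numbers for weaker inhibition. Compound 1 gives 23500 nM. Compound 2 reaches only a limit of the assay, > 100000 nM, so no number is known for it. Compound 3 likewise stops at a limit, > 100000 nM. The step of an at least 4.2-fold higher number from compound 1 to compound 2 (0.62 log units; beyond the scatter) is readable; the step that the two limits leave unreadable from compound 2 to compound 3 is not, because of the limit of > 100000 nM in this assay, at which 2 of the 3 values shown sit. Compound 2 therefore stands at the weak end of what the assay can report, with nothing closer than a limit to place it.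

Compound 4 `CCOC(=O)CNc1nc(Nc2ccc(OC)cc2)ncc1[N+](=O)[O-]` differs from compound 2 in one place: methoxy in place of chloro on an aromatic carbon. Neither measured step touches this part of the molecule; both change the substituent on the amine nitrogen, not the aromatic ring that carries the chloro group. No measured step therefore bears on this change, and no shift beyond the scatter can be predicted from the numbers shown in this assay. Compound 4 is expected to give about 120000 nM, somewhere between 30000 nM and 500000 nM. That estimate means an expected step that the limit leaves unreadable from compound 2 to compound 4, most likely again reported only as a limit.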

Compound 4, half-maximal inhibitory concentration: > 100000 nM
Compound 4 gave a limit, no number (the forecaster's own chance of this, stated with the estimate: 70%); the middle value lies beyond the limit too.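

Compound 2 and compound 4 both stop at a limit in this assay, so swapping chloro for methoxy gives no step that can be read: the limit of > 100000 nM in this assay, at which 3 of the 4 values shown sit.

The compounds shown leave open how 4-chlorophenyl and 4-methoxyphenyl compare in a compound whose value falls within the range the assay can report, such as compound 1.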